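Swapping One Halogen-Bearing Phenyl Group for Another

The source may hold more compounds than are shown below. What is called first, only, known or untested is meant among the compounds shown, and "the series" means these compounds.

- compound 1 `COc1cccc(/C=C2\CCC/C(=C\c3cccc(O)c3)C2=O)c1OC`: 8500 nM
- compound 2 `COc1ccc(/C=C2\CCC/C(=C\c3ccccc3Cl)C2=O)cc1OC`: 6800 nM

In a functional assay on HT-1080 cells (Homo sapiens) for cytotoxicity, read by MTT assay, with a stated time of 72 h (a higher number here means a weaker inhibitor, a lower number a stronger inhibitor), compound 2 gives 6800 nM. For the measured compounds named here, its only measured neighbour is compound 1, at 8500 nM. These two numbers lie within the usual scatter of repeated measurements, so they cannot be told apart.

Compound 3 `COc1ccc(/C=C2\CCC/C(=C\c3cccc(Br)c3)C2=O)cc1OC` carries 3-bromophenyl in place of 2-chlorophenyl on a double-bonded chain carbon bound to a double-bonded ring carbon. Going by the values given here, no measured pair shows the effect of this exact swap. Compared with compound 2, which differs from it in more than one place, compound 1 gives 8500 nM, so no change beyond the scatter is expected in this assay. The expected step of a 1.2-fold lower number from compound 2 to compound 3 (0.09 log units; within the scatter) is small and has no firm direction. For compound 3 the estimated value is 5500 nM, within an expected range of 1800 nM to 15000 nM.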

Compound 3, half-maximal inhibitory concentration: 5200 nM
Compound 3: middle estimate off by 1.1-fold (0.02 log units), on the high side; the range from low to high includes it.
By their numbers in this assay, from the lowest: compounds 3, 2 and 1 (each within the scatter of the next).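

In this assay, putting 3-bromophenyl in place of 2-chlorophenyl on a double-bonded chain carbon bound to a double-bonded ring carbon gives the first step tied to a single place on this scaffold (a 1.3-fold lower number from compound 2 to compound 3 (0.12 log units; within the scatter)). Here the halogen and its numbered ring position change together, yet the two compounds cannot be told apart, so this pair shows no effect of the combined change. Nothing measured here offers an explanation for this result.

This single step cannot separate the effect of the halogen from that of its ring position, as the two could differ in size or direction and still leave this result. On these data alone, whether a phenyl group bearing an amine or a carboxylic acid at this place would give a step beyond the scatter remains open.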